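The source may hold more compounds than are shown below. What is called first, only, known or untested is meant among the compounds shown, and "the series" means these compounds.

Measured so far:
Compound 1 `Cc1occc1-c1nnc2sc(-c3cc(O)nc(O)c3)nn12` gives 11.4% in a functional assay on the whole organism (strain Wistar Albino) for inhibition, with Rattus norvegicus as the target, read by paw edema, with a stated time of 2 h, at a dose of 20 mg/kg; on this read-out higher numbers stand for more inhibition at the one dose given (going by the name of the read-out) and lower numbers for less inhibition.
Compound 2 `COc1ccc(Cc2nnc3sc(-c4ccnc(Cl)c4)nn23)cc1OC` gives 13.3% in this assay.
Compound 3 `Cc1occc1-c1nnc2sc(-c3ccnc(Cl)c3)nn12` gives 15.3% in this assay.

All three compounds share the same core and differ in the groups attached to it. Compound 2 stands second highest of the three numbers in this assay, but its gap to compound 1 and its gap to compound 3 both lie within the usual scatter of repeated measurements, so the three values cannot be told apart with confidence.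

The next compound to be measured is compound 4 `COc1ccc(Cc2nnc3sc(-c4ccnc(F)c4)nn23)cc1OC`, which differs from compound 2 in one place: fluoro in place of chloro on an aromatic carbon. Among the compounds with values here, no measured pair in this set shows what a fluoro in place of chloro does here, so there is no step to lean on. Given that compound 1, compound 2 and compound 3 all sit in a narrow band, the expectation for compound 4 is a step of a number 0.3 percentage points lower from compound 2 to compound 4 (within the scatter), that is, no change beyond the scatter. Compound 4 is therefore estimated to give 13% in this assay, in a range from 6% to 20%.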

Compound 4, a percentage reported as inhibition, in the whole organism at one dose (the size of the read-out at that dose, not a potency): 14.3%
Compound 4: middle estimate off by 1.3 percentage points, on the low side; measured number inside the range.
By their numbers in this assay, from the lowest: compounds 1, 2, 4 and 3 (each within the scatter of the next).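

Within the data shown here, exchanging chloro for fluoro, which turns the 2-chloropyridin-4-yl group into 2-fluoropyridin-4-yl, gives the first one-place comparison in this set: in this assay the result is a number 1 percentage points higher from compound 2 to compound 4 (within the scatter). At this position, then, the read-out at the one dose given does not tell the two halogens apart, and a fluoro serves as well as a chloro in keeping the number where it stands. Nothing measured here offers an explanation for this result.

Among these compounds, still open is whether the same exchange would read alike with the other group on the shared core, the one carried by compound 3. Also open, from the compounds shown here alone, is whether an amine or a nitrile in place of the halogen, at this same carbon, would move the number beyond the scatter.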